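Working notes: cytotoxicity across compounds 1 to 4

This account rests on a few compounds, and the source may have more. Where it says the series, first, only, none or still open, it means among the compounds named here.

Measured so far:
compound 1, `N#Cc1cnc(C(N)=O)c(NCc2ccccc2)n1`: "not determined" (no result reported)
compound 2, `N#Cc1cnc(C(N)=O)c(NCc2ccc(N)cc2)n1`: > 1000000 nM
compound 3, `N#Cc1cnc(C(N)=O)c(NCc2ccc(Cl)cc2)n1`: "not determined" (no result reported)

In an ADME assay on HepG2 cells (Homo sapiens) for cytotoxicity (a lower number here means a stronger inhibitor, a higher number a weaker inhibitor), compound 1 has no single number. Of the two further entries in this assay, one is a limit and one is without a number. The value of compound 2 in this assay is a limit of the assay, not a number. Compound 3 is without a result in this assay. Going by the values given here, the one piece of evidence in this assay is the limit of > 1000000 nM in this assay, at which 1 of the 3 values shown sits, so nothing here sizes a step between any two measured compounds.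

Compound 4, `N#Cc1cnc(C(N)=O)c(NCc2cccc([N+](=O)[O-])c2)n1`, differs from compound 1 by nitro in place of hydrogen on an aromatic carbon, meta to a large group. Among the compounds with values here, no step between measured compounds is known, and compound 1 itself has no number, so the step in this assay from compound 1 to compound 4 cannot be anchored. The one figure available in this assay sits at the limit, and a step of no more than the usual scatter, in no set direction, is what is expected for this change.

For compound 4 the estimated value in this assay is 500000 nM, with a range from 50000 nM to 2000000 nM.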

Compound 4, half-maximal inhibitory concentration: 457000 nM
Compound 4: the middle estimate sits 1.1-fold (0.04 log units) above what was measured, within the range that was stated.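

In this assay compound 4 gives 457000 nM, yet no new step can be read from this result: compound 1 has no single number to set against it. The compounds shown leave open how far nitro in place of hydrogen, meta to a large group, shifts the value in this assay from that of compound 1.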